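This account rests on a few compounds, and the source may have more. Where it says the series, first, only, none or still open, it means among the compounds named here.

Going by the values given here, in a functional assay on MKN-45 cells (Homo sapiens) for inhibition, read by CCK-8 assay, with a stated time of 24 h (on this read-out higher numbers stand for weaker inhibition and lower numbers for stronger inhibition), compound 3 `Cc1ccc(-n2cc(-c3ccc(/C=C4\C(=O)Nc5ccc(F)cc54)cc3)nn2)cc1` gives 34600 nM, the higher of the two true numbers so far, while compound 2 `Cc1cccc(-n2cc(-c3ccc(/C=C4\C(=O)Nc5ccc(F)cc54)cc3)nn2)c1` gives 6810 nM. Compound 1 `O=C1Nc2ccccc2/C1=C/c1ccc(-c2cn(-c3ccccc3Cl)nn2)cc1` reads > 20000 nM, which is a limit of the assay and not a number. Compound 4 `O=C1Nc2ccc(F)cc2/C1=C/c1ccc(-c2cn(-c3cccc(F)c3)nn2)cc1` is still unmeasured, and it differs from compound 3 as follows: 3-fluorophenyl in place of 4-methylphenyl on an aromatic nitrogen. In words, 3-fluorophenyl stands in place of 4-methylphenyl on an aromatic nitrogen. Among the compounds with values here, one measured step bears on this: a 5.1-fold higher number from compound 2 to compound 3 (0.71 log units; beyond the scatter), with 4-methylphenyl in place of 3-methylphenyl. Compound 4 carries 3-fluorophenyl, as against 4-methylphenyl in compound 3 and 3-methylphenyl in compound 2, but fluoro is not methyl, so only a partial return is expected. The expected change is a 2.9-fold lower number from compound 3 to compound 4 (0.46 log units; beyond the scatter). Compound 4 is estimated at 12000 nM, with an expected range of 3500 nM to 35000 nM.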

Compound 4, half-maximal inhibitory concentration: 8190 nM
Beside the measured number, compound 4's estimate is 1.5-fold (0.17 log units) above it; the measured number falls inside the stated range.
By their numbers in this assay, from the lowest: compounds 2 and 4 (each within the scatter of the next); then compound 3.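

In this assay, 3-fluorophenyl in place of 4-methylphenyl gives a 4.2-fold lower number from compound 3 to compound 4 (0.63 log units; beyond the scatter) and fluoro in place of methyl on an aromatic carbon gives a 1.2-fold higher number from compound 2 to compound 4 (0.08 log units; within the scatter) within one series. So the two groups, 3-methylphenyl and 3-fluorophenyl, cannot be told apart on this read-out. Of the three compounds with true numbers, only compound 3, with 4-methylphenyl, stands apart.

On these data alone, whether an amine or a carboxylic acid in place of the fluoro of compound 4 would read the same stays open. Nothing measured here gives a reason for these numbers.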